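Benzyl ether variation on a piperazine-linked isoxazole scaffold

The source may hold more compounds than are shown below. What is called first, only, known or untested is meant among the compounds shown, and "the series" means these compounds.

Two measured compounds share one core and differ only in the aryl group of the benzyl ether. Compound 1 `Cc1cc(C)cc(COc2ccc(-c3cc(CN4CCN(Cc5ccc(C(F)(F)F)cc5)CC4)no3)cc2)c1` carries a 3,5-dimethylphenyl group there and in a functional assay on Mahlavu cells (Homo sapiens) for antiproliferative activity, read by sulforhodamine B assay, with a stated time of 72 h (on this read-out lower numbers stand for stronger inhibition and higher numbers for weaker inhibition), compound 1 gives 6000 nM. Compound 2 `N#Cc1ccccc1COc1ccc(-c2cc(CN3CCN(Cc4ccc(C(F)(F)F)cc4)CC3)no2)cc1` carries a 2-cyanophenyl group instead, and in this assay compound 2 gives 3500 nM. The move between them is a 1.7-fold lower number from compound 1 to compound 2 (0.23 log units; within the scatter), so compound 2 has the lower of the two numbers without standing apart from compound 1 beyond the scatter.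

Compound 3 `COc1ccc(COc2ccc(-c3cc(CN4CCN(Cc5ccc(C(F)(F)F)cc5)CC4)no3)cc2)cc1` continues this line of variation: 4-methoxyphenyl in place of 2-cyanophenyl on a saturated chain carbon bound to an oxygen on an aromatic ring. For the measured compounds named here, the only step that bears on this position is the one from compound 1 to compound 2, and that step stayed within the scatter; nothing measured here suggests that a change at this position moves this assay by more than the scatter. Compound 3 is therefore expected to land close to compound 2, with a 1.1-fold higher number from compound 2 to compound 3 (0.06 log units; within the scatter) as the expected step and no direction claimed beyond the scatter. The estimate for compound 3 in this assay is 4000 nM, with a range from 1500 nM to 10000 nM.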

Compound 3, half-maximal inhibitory concentration: 4900 nM
The estimate for compound 3 lay 1.2-fold (0.09 log units) below the measured number; low and high end bracket the measured number.
By their numbers in this assay, from the lowest: compounds 2, 3 and 1 (each within the scatter of the next).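

In this assay, the third group widens what the first pair suggested: with a 1.4-fold higher number from compound 2 to compound 3 (0.15 log units; within the scatter) and a 1.2-fold lower number from compound 1 to compound 3 (0.09 log units; within the scatter), all three pairs now sit within the scatter, so 2-cyanophenyl, 3,5-dimethylphenyl and 4-methoxyphenyl cannot be told apart at this position. The new step also shows that exchanging 2-cyanophenyl for 4-methoxyphenyl, two groups of equal heavy-atom count that differ in their substituent and in where the name places it, gives no change that can be read in this assay. Nothing available here accounts for this insensitivity, and no independent data bear on it.

Going by these compounds, all three compounds carry a substituted phenyl ring at this place, so it remains open whether a carboxylic acid or a primary amine on that ring, or a longer chain in place of the single saturated carbon bound to the oxygen, would move the number beyond the scatter. The rest of the shared core is identical in compounds 1, 2 and 3, so these results say nothing about changes made elsewhere on it.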